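Trimming the diamine side chain: compound 3 to compound 4

The source may hold more compounds than are shown below. What is called first, only, known or untested is meant among the compounds shown, and "the series" means these compounds.

Three compounds share a core carrying a thioether side chain, and all three have been measured in a functional assay on HT cells (Homo sapiens) for antiproliferative activity, read by fluorescence, with a stated time of 72 h; a lower number here means a stronger inhibitor of growth, a higher number a weaker inhibitor of growth. Compound 1 `CC(O)CSc1nc(NCc2ccc(-c3ccccn3)cc2)c2[nH]nc(C(C)C)c2n1` gives 62 nM in this assay, compound 2 `CC(C)c1n[nH]c2c(NCc3ccc(-c4ccccn4)cc3)nc(SCCCN(C)C)nc12` gives 105 nM, and compound 3 `CC(C)c1n[nH]c2c(NCc3ccc(-c4ccccn4)cc3)nc(SCC(N)CN)nc12` gives 480 nM. On these numbers compound 3 stands highest: the step of a 7.7-fold higher number from compound 1 to compound 3 (0.89 log units; beyond the scatter) and the step of a 4.6-fold higher number from compound 2 to compound 3 (0.66 log units; beyond the scatter) are both beyond the scatter, while the step of a 1.7-fold higher number from compound 1 to compound 2 (0.23 log units; within the scatter) is within it.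

Compound 4 `CC(C)c1n[nH]c2c(NCc3ccc(-c4ccccn4)cc3)nc(SCCCN)nc12` differs from compound 3 in one place: hydrogen in place of amino on a saturated chain carbon bound to two saturated chain carbons. The resulting (3-aminopropyl)sulfanyl chain sits between the 2,3-diaminopropyl chain of compound 3 and the (dimethylamino)propyl chain of compound 2. The step from compound 2 to compound 3 bears most directly on this change, since removing the amino undoes part of it; the number for compound 4 is therefore expected to fall back toward that of compound 2, by a step of a 3.2-fold lower number from compound 3 to compound 4 (0.51 log units; beyond the scatter). Compound 4 is thus estimated at 150 nM, within a range of 60 nM to 400 nM.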

Compound 4, concentration for 50% growth inhibition: 120 nM
Beside the measured number, compound 4's estimate is 1.3-fold (0.10 log units) above it; the measured number falls inside the stated range.
By their numbers in this assay, from the lowest: compounds 1, 2 and 4 (each within the scatter of the next); then compound 3.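

In this assay, taking the amino off the chain carbon bound to two saturated chain carbons gives a 4.0-fold lower number from compound 3 to compound 4 (0.60 log units; beyond the scatter), so the high number of compound 3 goes with that single amino group rather than with the chain as a whole. The other two steps stay within the scatter, a 1.1-fold higher number from compound 2 to compound 4 (0.06 log units; within the scatter) and a 1.9-fold higher number from compound 1 to compound 4 (0.29 log units; within the scatter), so this assay does not separate the (3-aminopropyl)sulfanyl chain from the chains of compound 1 and compound 2. Nothing measured here explains why the extra amino goes with a higher number.

From the compounds shown here alone, it remains open whether a hydroxyl or a methoxy on that same chain carbon would raise the number as the amino does. A longer chain, a carboxylic acid at the chain end, or a cyclic amine such as piperidine could also behave differently from the chains shown here.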